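The compounds below may be only part of what the source reports. "The series", "measured", "known", "first", "only" and "open" are said of these compounds alone.

Compound 1, with the structure `CCCC(=O)C1=C(C)NC(=O)NC1c1cccs1`, is the starting point. In an assay on membranes from CHO cells for displacement of a labelled ligand from adenosine receptor A1 (Homo sapiens), read by scintillation counting, with a stated time of 60 min, tested at 1 uM (on this read-out lower numbers stand for less inhibition and higher numbers for more inhibition at the one concentration tested (going by the name of the read-out)), compound 1 gives 2%. Compound 2, with the structure `CCCC(=O)C1=C(C)NC(=O)NC1c1ccsc1`, differs from compound 1 by thiophen-3-yl in place of thiophen-2-yl on a saturated ring carbon. In this assay compound 2 gives 6%, so the move produced a number 4 percentage points higher from compound 1 to compound 2 (within the scatter). Compound 3, with the structure `CC1=C(c2ncc(C)o2)C(c2cccs2)NC(=O)N1`, carries a different core; the difference from compound 1 is 5-methyl-1,3-oxazol-2-yl in place of propylcarbonyl on a double-bonded ring carbon. In this assay compound 3 gives 21%, the highest of the three numbers, and the move from compound 1 gave a number 19 percentage points higher from compound 1 to compound 3 (beyond the scatter).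

Compound 4, with the structure `CC1=C(c2ncc(C)o2)C(c2ccsc2)NC(=O)N1`, has not yet been measured in this assay. It differs from compound 3 by thiophen-3-yl in place of thiophen-2-yl on a saturated ring carbon. Going by the values given here, this is the same kind of change as the one from compound 1 to compound 2, though the surroundings differ: in compound 1 the saturated ring carbon is next to the ring atom that bears a propylcarbonyl group, whereas in compound 3 it is next to the ring atom that bears a 5-methyl-1,3-oxazol-2-yl group. Among the compounds with values here, the only guide is the earlier move, which gave a number 4 percentage points higher from compound 1 to compound 2 (within the scatter), a shift inside the scatter. The expected step from compound 3 to compound 4 is therefore estimated as a number 3 percentage points higher from compound 3 to compound 4 (within the scatter), a small move, resting on that single precedent. On this basis compound 4 is expected to give about 24% in this assay, most likely between 8% and 40%.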

Compound 4, a percentage reported as inhibition, at one concentration (the size of the read-out at that concentration, not a potency): 34%
Estimate against measurement, compound 4: 10 percentage points below; the range from low to high includes it.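

In this assay, putting thiophen-3-yl in place of thiophen-2-yl gave a number 13 percentage points higher from compound 3 to compound 4 (beyond the scatter), and this step agrees with the same change on the core of compound 1: the same change on two cores in this assay, a number 4 percentage points higher (within the scatter) from compound 1 to compound 2 and a number 13 percentage points higher (beyond the scatter) from compound 3 to compound 4, 9 percentage points apart, within the scatter of two such steps Putting 5-methyl-1,3-oxazol-2-yl in place of propylcarbonyl gave a number 28 percentage points higher from compound 2 to compound 4 (beyond the scatter), and this step likewise agrees with its earlier counterpart: the same change on two cores in this assay, a number 19 percentage points higher (beyond the scatter) from compound 1 to compound 3 and a number 28 percentage points higher (beyond the scatter) from compound 2 to compound 4, 9 percentage points apart, within the scatter of two such steps So within these four compounds each change behaved much the same on both cores, but this rests on a single pair of steps per change, read at one concentration, and it neither fixes the true size of the thiophene step, which lies within the scatter on one core and beyond it on the other, nor shows that the agreement would hold on any other core.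

The compounds shown leave open whether other groups would follow the same pattern, such as a longer chain or a carboxylic acid in place of the 5-methyl-1,3-oxazol-2-yl group, or a phenyl ring in place of the thiophene. They also leave open how these percentages at one concentration would translate into potency.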